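Moving the chlorine on the aryl piperazine

The source may hold more compounds than are shown below. What is called first, only, known or untested is meant among the compounds shown, and "the series" means these compounds.

Of the compounds shown here, three sharing one core have been measured in an assay on a cell-free system (plasma) for inhibition of Dipeptidyl peptidase 4 (Rattus norvegicus), read by fluorescence; a higher number here means a weaker inhibitor, a lower number a stronger inhibitor. Compound 1 `O=C([C@@H]1C[C@H](N2CCN(c3ccccn3)CC2)CN1)N1CCSC1` gives 3.5 nM. Compound 2 `COc1ccc(N2CCN([C@@H]3CN[C@H](C(=O)N4CCSC4)C3)CC2)cc1` gives 16.9 nM. Compound 3 `O=C([C@@H]1C[C@H](N2CCN(c3ccccc3Cl)CC2)CN1)N1CCSC1` gives 10.9 nM, the second highest of the three numbers; the step of a 3.1-fold higher number from compound 1 to compound 3 (0.49 log units; beyond the scatter) lies beyond the scatter, whereas the step of a 1.6-fold lower number from compound 2 to compound 3 (0.19 log units; within the scatter) lies within it.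

Compound 4 `O=C([C@@H]1C[C@H](N2CCN(c3ccc(Cl)cc3)CC2)CN1)N1CCSC1` differs from compound 3 only in 4-chlorophenyl in place of 2-chlorophenyl on an amine nitrogen in a ring. Within the data shown here, no measured step moves a substituent around the aryl ring while keeping it the same; the nearest comparison is the step of a 1.6-fold lower number from compound 2 to compound 3 (0.19 log units; within the scatter), which swaps one substituted phenyl for another at the same ring nitrogen and stays within the scatter. The steps of a 4.8-fold higher number from compound 1 to compound 2 (0.68 log units; beyond the scatter) and a 3.1-fold higher number from compound 1 to compound 3 (0.49 log units; beyond the scatter) show that leaving the pyridin-2-yl group costs modestly, but both chlorophenyl variants keep that change in common. Compound 4 is therefore expected to sit close to compound 3, with a step of about a 1.1-fold higher number from compound 3 to compound 4 (0.04 log units; within the scatter) that is not expected to exceed the scatter. Compound 4 is estimated at 12 nM, expected to lie between 4 nM and 35 nM.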

Compound 4, half-maximal inhibitory concentration: 10.3 nM
Compound 4: the middle estimate sits 1.2-fold (0.07 log units) above what was measured, within the range that was stated.
By their numbers in this assay, from the lowest: compound 1; then compounds 4, 3 and 2 (each within the scatter of the next).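

Changing 2-chlorophenyl to 4-chlorophenyl on an amine nitrogen in a ring gives a 1.1-fold lower number from compound 3 to compound 4 (0.02 log units; within the scatter) in this assay, and chloro in place of methoxy on an aromatic carbon gives a 1.6-fold lower number from compound 2 to compound 4 (0.22 log units; within the scatter), so neither change separates these compounds in this assay. The pyridin-2-yl group stays apart from this third substituted phenyl as well, with a 2.9-fold higher number from compound 1 to compound 4 (0.47 log units; beyond the scatter). No measurement bearing on these results is available to explain them.

The compounds shown leave open whether pyrimidin-2-yl or pyridin-4-yl on that amine nitrogen would match compound 1, and whether a phenyl carrying a carboxylic acid or an amine would stay level with compounds 2, 3 and 4. They also leave open whether these relations would hold with a different amide on the shared core.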